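Cytotoxicity of Biaryl Hydroxyalkanols in J774 Cells

The source may hold more compounds than are shown below. What is called first, only, known or untested is meant among the compounds shown, and "the series" means these compounds.

In a functional assay on J774 cells (Mus musculus) for cytotoxicity, read by resazurin assay (a higher number here means a weaker inhibitor, a lower number a stronger inhibitor), two compounds have been measured. Compound 1 `OCCCCCC(O)c1ccc(-c2ccc(F)cc2F)cc1` gives 8000 nM, and compound 2 `Cc1ccccc1-c1ccc(C(O)CCCCCO)cc1` gives 24000 nM. Compound 2 therefore stands at the higher of the two numbers, the weaker inhibitor of the pair, its nearest neighbour being compound 1 with a number lower by an amount beyond the usual scatter.

Compound 3 `OCCCCCC(O)c1ccc(-c2cccc(Cl)c2)cc1` has not yet been measured. Its structure differs from compound 2 in one respect (3-chlorophenyl in place of 2-methylphenyl on an aromatic carbon). Among the compounds with values here, no step between measured compounds covers this kind of change, so the direction rests only on compound 1, whose value 8000 nM shows that a halogen-bearing aryl ring can give a lower number than the methyl-bearing ring of compound 2. The step of a 2.0-fold lower number from compound 2 to compound 3 (0.30 log units; within the scatter) is expected to be modest and downward, close to the edge of the scatter. Compound 3 is estimated at 12000 nM, within a range from 5000 nM to 30000 nM.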

Compound 3, half-maximal inhibitory concentration: > 100000 nM
Compound 3: a limit, no number (the forecaster's own chance of this, stated with the estimate: 10%); middle value at least 8.3-fold (0.92 log units) from the limit.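

Within the data shown here, the first step at this position shows that the aryl group is not a neutral place: putting 3-chlorophenyl in place of 2-methylphenyl on an aromatic carbon, with the heavy-atom count unchanged, gives an at least 4.1-fold higher number from compound 2 to compound 3 (0.61 log units; beyond the scatter). A chlorine-bearing ring therefore does not of itself bring a lower number in this assay, and this exchange moves the number upward. The size of the step remains open-ended, as the result for compound 3 is a limit of the assay and not a number: the limit of > 100000 nM in this assay, at which 1 of the 3 values shown sits.

Chlorine replaces methyl and the substituent's ring position changes in the same step, so the two effects cannot be separated here; 3-methylphenyl or 2-chlorophenyl would be needed to do that. From the compounds shown here alone, how an amine, a carboxylic acid or a longer chain would behave in this assay also remains open.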